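Working notes: from compound 2 to compound 3

The source may hold more compounds than are shown below. What is called first, only, known or untested is meant among the compounds shown, and "the series" means these compounds.

- compound 1 `CCCOP(=O)(O)OCCSC(=S)N1CCCCC1` gives > 100000 nM as a limit
- compound 2 `CCCCCCCCCCOP(=O)(O)OCCSC(=S)N1CCN(C)CC1` gives 80000 nM

Both entries come from a functional assay on PC-3 cells (Homo sapiens) for inhibition, read by MTT assay, with stated times of 18 h and 4 h (a higher number here means a weaker inhibitor, a lower number a stronger inhibitor), as the only read-out in this series. The entry for compound 1 at > 100000 nM is a limit of the assay and not a number. Among the compounds with values here, compound 2 at 80000 nM therefore holds the only true number available, and it serves as the anchor for what follows.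

Compound 3 `CCCCCCCCCCOP(=O)(O)OCCSC(=S)N1CCCCC1` differs from compound 2 in one place, on a thiocarbonyl carbon, with piperidin-1-yl in place of 4-methylpiperazin-1-yl on a thiocarbonyl carbon as the whole change. It shares piperidin-1-yl with compound 1 and everything else with compound 2. Within the data shown here, no measured pair isolates this change: compound 1 and compound 2 differ in more than one place.

With only compound 2 at 80000 nM to go on, a small move toward a lower number is expected in this assay and it may stay within the scatter. The expected size is a 1.3-fold lower number from compound 2 to compound 3 (0.12 log units; within the scatter) as a rough estimate. Compound 3 is estimated at 60000 nM with an expected range from 20000 nM to 100000 nM in this estimate.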

Compound 3, half-maximal inhibitory concentration: 62500 nM
For compound 3 the middle estimate is 1.0-fold (0.02 log units) below the measured one; the range from low to high includes it.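

In this assay, within the data shown here, the first pair that differs in one place gives a 1.3-fold lower number from compound 2 to compound 3 (0.11 log units; within the scatter), so on a thiocarbonyl carbon whose other neighbour is sulfur, the two rings cannot be told apart in this read-out, even though 4-methylpiperazin-1-yl carries a second ring nitrogen that piperidin-1-yl lacks. The second pair isolates the chain, with heptyl in place of hydrogen on a saturated chain carbon, three bonds along the chain from an oxygen on an unsaturated carbon, and gives an at least 1.6-fold lower number from compound 1 to compound 3 (0.20 log units; that floor lies within the scatter). Compound 1 gives > 100000 nM, which is a limit of the assay and not a number, so this chain step can be read only as a floor and its true size stays unknown: the limit of > 100000 nM in this assay, at which 1 of the 3 values shown sits.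

Open, as far as these compounds go, is whether a still longer chain at that saturated chain carbon, or a morpholine ring or an open-chain amine such as diethylamino on the thiocarbonyl carbon, would carry the number beyond the scatter. From the compounds shown here alone, the ring comparison also rests on the longer chain alone, so whether 4-methylpiperazin-1-yl and piperidin-1-yl stay level with the shorter chain of compound 1 remains open.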